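Compound 2: carboxy to methoxycarbonyl

The source may report more compounds than this note shows. Statements on the series, on what has been measured and on what is new or still open speak of the compounds shown alone.

In an ADME assay for permeability, using PAMPA, at pH 7.4 (on this read-out higher numbers stand for higher permeability and lower numbers for lower permeability), compound 1 (`O=C(O)COc1cc(Cl)c(C(=O)Nc2cccc(-c3nc4ccccc4s3)c2)cc1[N+](=O)[O-]`) gives < 1 10^-6 cm/s and that value is a limit of the assay. Compound 2 (`Cc1ccc(-c2nc3ccccc3s2)cc1NC(=O)c1cc([N+](=O)[O-])c(N2CCC(C(=O)O)CC2)cc1Cl`) reads 17 10^-6 cm/s as the lower of the two numbers that are not limits, and compound 3 (`O=C(Nc1cccc(-c2nc3ccccc3s2)c1)c1cc([N+](=O)[O-])c(O)cc1Cl`) reads 307 10^-6 cm/s on the same scale. Compound 4 (`COC(=O)C1CCN(c2cc(Cl)c(C(=O)Nc3cc(-c4nc5ccccc5s4)ccc3C)cc2[N+](=O)[O-])CC1`) has methyl in place of hydrogen on an oxygen next to a carbonyl group of compound 2 (methyl in place of hydrogen on an oxygen next to a carbonyl group), so carboxy becomes methoxycarbonyl. Going by the values given here, only one measured step bears on this, and loosely: hydrogen in place of carboxymethyl, which also takes away a carboxy group. That step (an at least 300-fold higher number from compound 1 to compound 3 (2.48 log units; beyond the scatter)) is large, but it is a different change, so a smaller rise, still beyond the scatter, is expected in this assay here. The expected step (a 5.3-fold higher number from compound 2 to compound 4 (0.72 log units; beyond the scatter)) is an estimate only. Compound 4 is estimated at 90 10^-6 cm/s with a range from 25 10^-6 cm/s to 320 10^-6 cm/s as its expected span.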

Compound 4, apparent permeability: 24 10^-6 cm/s
Beside the measured number, compound 4's estimate is 3.8-fold (0.57 log units) above it, and the stated range ends above it.
By their numbers in this assay, from the lowest: compounds 2 and 4 (each within the scatter of the next); then compound 3. At a limit, below all of these: compound 1.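

In this assay, 4-carboxypiperidin-1-yl to 4-(methoxycarbonyl)piperidin-1-yl gives a 1.4-fold higher number from compound 2 to compound 4 (0.15 log units; within the scatter), so the carboxy group and its methyl ester read alike at this position. The earlier compounds shown here showed only the loss of a whole carboxymethyl group on a different scaffold; here, methyl on the carboxy oxygen alone gives no step beyond the scatter. Nothing measured here bears on why this step is so small.

Open, on these data alone, is whether a primary amide or a longer ester chain at this position would also read alike. Also open, as far as these compounds go, is whether a methyl ester of the carboxymethyl group of compound 1 would behave as compound 4 does.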